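Opening a ring on a weak topoisomerase inhibitor

The source may report more compounds than this note shows. Statements on the series, on what has been measured and on what is new or still open speak of the compounds shown alone.

Measured so far:
- compound 1 `CN[C@@H]1CCN(c2cc3c(cc2F)c(=O)c(C(=O)O)cn3Cc2ccc(-c3ccccc3)cc2)C1`: 34800 nM
- compound 2 `O=C(O)c1cn(Cc2ccc(-c3ccccc3)cc2)c2cc(NC[C@@H]3CCNC3)c(F)cc2c1=O`: 104000 nM

In an assay on isolated protein for inhibition of DNA topoisomerase 1 (Homo sapiens), with a stated time of 15 min (a lower number here means a stronger inhibitor, a higher number a weaker inhibitor), compound 2 gives 104000 nM, the highest of the two numbers shown, so compound 2 is the weaker of the pair. Its nearest neighbour is compound 1, and the change between them amounts to a 3.0-fold higher number from compound 1 to compound 2 (0.48 log units; beyond the scatter).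

Compound 3 `CNCCCCNc1cc2c(cc1F)c(=O)c(C(=O)O)cn2Cc1ccc(-c2ccccc2)cc1` has not been measured. It differs from compound 2 in one place: 3-(methylamino)propyl in place of pyrrolidin-3-yl on a saturated chain carbon bound to a nitrogen on an aromatic ring. Among the measured compounds shown here, the one measured step, from compound 1 to compound 2, exchanged a group on the aromatic ring itself and does not touch the chain that is altered here, so it gives only an indirect hint that changes around this nitrogen can shift the number by a modest amount. For the measured compounds named here, no measured step describes opening this five-membered ring into a chain. The expectation for compound 3 is therefore no step beyond the scatter, written as a 1.0-fold lower number from compound 2 to compound 3 (0.02 log units; within the scatter). On that basis compound 3 is estimated at 100000 nM, with a range from 35000 nM to 280000 nM.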

Compound 3, half-maximal inhibitory concentration: 88300 nM
The estimate for compound 3 lay 1.1-fold (0.05 log units) above the measured number; the range from low to high includes it.
By their numbers in this assay, from the lowest: compound 1; then compounds 3 and 2 (each within the scatter of the next).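

In this assay, putting the open chain 3-(methylamino)propyl in place of the ring pyrrolidin-3-yl gives a 1.2-fold lower number from compound 2 to compound 3 (0.07 log units; within the scatter) and so no change that this assay can separate from noise. At this place, on a saturated chain carbon bound to a nitrogen on an aromatic ring, the ring and its defined stereocentre can therefore be given up without a visible cost, at least for this pair, in which both groups have the same count of heavy atoms. The open chain does not close the distance to the directly attached ring of compound 1, since the change to (4-(methylamino)butyl)amino gives a 2.5-fold higher number from compound 1 to compound 3 (0.40 log units; beyond the scatter) and compound 2 also stands beyond the scatter from compound 1. Nothing shown here explains these numbers.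

The compounds shown leave open whether a shorter or longer chain would move the number, since only one chain length appears among them. They also leave open what happens if the methylamino end of the chain gives way to a primary amine, a dimethylamino group or a hydroxyl group.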